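This account rests on a few compounds, and the source may have more. Where it says the series, first, only, none or still open, it means among the compounds named here.

Compound 1 `O=S(=O)(NC1CCN(S(=O)(=O)c2ccccc2)CC1)c1cc(S(=O)(=O)c2ccccc2)ccc1C(F)(F)F`: 130 nM
Compound 2 `CC(C)(C)OC(=O)N1CCC(C(=O)N2CCC(NS(=O)(=O)c3cc(S(=O)(=O)c4ccccc4)ccc3C(F)(F)F)CC2)CC1`: 300 nM

Of the two compounds measured in an assay on isolated protein for displacement of a labelled ligand from secreted frizzled-related protein 1 (Homo sapiens), read by fluorescence polarization, with a stated time of 30 min (a higher number here means a weaker inhibitor, a lower number a stronger inhibitor), compound 1 holds the lower number, and compound 2 stands above it by more than the usual scatter. Compound 3 `O=C([C@@H]1CCNC1)N1CCC(NS(=O)(=O)c2cc(S(=O)(=O)c3ccccc3)ccc2C(F)(F)F)CC1` has not yet been measured. It differs from compound 1 in one place: (pyrrolidin-3-yl)carbonyl in place of phenylsulfonyl on an amine nitrogen in a ring. Among the measured compounds shown here, no measured pair shows this change, so the expected step of a 2.2-fold higher number from compound 1 to compound 3 (0.33 log units; beyond the scatter) is a moderate rise, guided by compound 2, whose value of 300 nM lies above compound 1. For compound 3 the expected value in this assay is 280 nM, within an estimated range from 90 nM to 900 nM.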

Compound 3, half-maximal inhibitory concentration: 60 nM
Compound 3: middle estimate off by 4.7-fold (0.67 log units), on the high side, outside the stated range (below it).
By their numbers in this assay, from the lowest: compound 3; then compound 1; then compound 2.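

On the amine nitrogen in the six-membered ring, in this assay, replacing phenylsulfonyl with (pyrrolidin-3-yl)carbonyl gives a 2.2-fold lower number from compound 1 to compound 3 (0.34 log units; beyond the scatter), so this position does not depend on the phenylsulfonyl group. The aromatic ring can go here, and a smaller group with a non-aromatic ring, a hydrogen-bond donor and a defined stereocentre can take its place. Nothing available explains why the number falls.

Which part of the new group matters remains open. An acetyl group, which has only the carbonyl, or a pyrrolidine with a methyl group on its nitrogen, would help separate these contributions, as would the opposite stereoisomer.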